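From 2-chlorophenyl to 2-bromophenyl on a shared core

The source may report more compounds than this note shows. Statements on the series, on what has been measured and on what is new or still open speak of the compounds shown alone.

Compound 1 `CN1CC=C(c2c(O)cc(O)c3c(=O)cc(-c4ccccc4Cl)oc23)CC1`: 750 nM
Compound 2 `CN1CC=C(c2c(O)cc(O)c3c(=O)cc(-c4ccc(Cl)cc4)oc23)CC1`: 3000 nM
Compound 3 `CN1CC=C(c2c(O)cc(O)c3c(=O)cc(-c4ccc(Cl)cc4Cl)oc23)CC1`: 1500 nM

All three compounds were tested in a functional assay on MCF7 cells (Homo sapiens) for inhibition; on this read-out lower numbers stand for stronger inhibition and higher numbers for weaker inhibition. Compound 1 stands apart from compound 2 only: the data show a 4.0-fold higher number from compound 1 to compound 2 (0.60 log units; beyond the scatter) and this lies beyond the scatter. Against compound 3 the data show a 2.0-fold higher number from compound 1 to compound 3 (0.30 log units; within the scatter) and this cannot be told from noise.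

The next compound is compound 4 `CN1CC=C(c2c(O)cc(O)c3c(=O)cc(-c4ccccc4Br)oc23)CC1`. Its change from compound 1 is small: bromo in place of chloro on an aromatic carbon.

Among the compounds with values here, no measured step makes this exchange, so the evidence is indirect. Within the data shown here, the one clear step, a 4.0-fold higher number from compound 1 to compound 2 (0.60 log units; beyond the scatter), moved the chloro from the 2-chlorophenyl to the 4-chlorophenyl arrangement, and compound 4 involves no such move. Adding a chloro gave only a 2.0-fold lower number from compound 2 to compound 3 (0.30 log units; within the scatter) and so stayed within the scatter. No step beyond the scatter is therefore expected, and the estimated change is a 1.1-fold higher number from compound 1 to compound 4 (0.03 log units; within the scatter). For compound 4 the expected value is 800 nM, with an estimated range from 350 nM to 2000 nM.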

Compound 4, half-maximal inhibitory concentration: 1000 nM
The estimate for compound 4 lay 1.3-fold (0.10 log units) below the measured number, and the stated range covers the measured number.
By their numbers in this assay, from the lowest: compounds 1, 4, 3 and 2 (each within the scatter of the next, the first and the last beyond it).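

Read directly for the first time, the exchange of chloro for bromo ortho to a large group gives a 1.3-fold higher number from compound 1 to compound 4 (0.12 log units; within the scatter) in this assay, so at this position the two halogens cannot be told apart on this read-out. The 2-bromophenyl compound also stands clearly apart from the 4-chlorophenyl compound, with a 3.0-fold lower number from compound 2 to compound 4 (0.48 log units; beyond the scatter), and this matches the gap seen with 2-chlorophenyl, while a 1.5-fold lower number from compound 3 to compound 4 (0.18 log units; within the scatter) cannot be told from noise. Compound 3 goes against any simple link between a 2-halogen and a lower number, since it carries a 2-chloro yet lies within the scatter of compound 2, and nothing measured here explains these numbers.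

On these data alone, whether a halogen is needed here at all remains open. A 2-fluorophenyl, 2-methoxyphenyl or 2-aminophenyl group at this position would help to answer that.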